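The source may report more compounds than this note shows. Statements on the series, on what has been measured and on what is new or still open speak of the compounds shown alone.

Measured so far:
Compound 1, `Cn1c(CN2CCC(c3ccccc3)CC2)nc2ccccc21`, in a functional assay on CHO cells for agonist activity at metabotropic glutamate receptor 2 (Homo sapiens), read by FLIPR (on this read-out higher numbers stand for an effect only at larger amounts of compound and lower numbers for an effect already at smaller amounts), gives 6310 nM.
Compound 2, `Cn1c(CN2CCC(c3ccccc3C(F)(F)F)CC2)nc2ccccc21`, in this assay gives 6310 nM.

Compound 1 stands level with compound 2 on this read-out; its nearest neighbour is compound 2, and the step of no change at the digits printed from compound 1 to compound 2 (within the scatter) shows no change within the scatter. Compound 3, `Cn1c(CN2CCC(c3cccc(C(F)(F)F)c3)CC2)nc2ccccc21`, has not yet been measured. It differs from compound 1 in one place: trifluoromethyl in place of hydrogen on an aromatic carbon. Going by the values given here, the one measured step that bears on this change is no change at the digits printed from compound 1 to compound 2 (within the scatter), in which the same trifluoromethyl group entered the same ring at another carbon and left the half-maximal effective concentration where it was. On that basis the change to compound 3 is expected to give no change at the digits printed from compound 1 to compound 3 (within the scatter), that is, nothing beyond the scatter. Compound 3 is therefore estimated at 6310 nM, with a range from 2500 nM to 16000 nM.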

Compound 3, half-maximal effective concentration: 2510 nM
Estimate against measurement, compound 3: 2.5-fold (0.40 log units) above; the measured number falls inside the stated range.
By their numbers in this assay, from the lowest: compound 3; then compounds 1 and 2 (each within the scatter of the next).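

In this assay, going by these compounds alone, the step of a 2.5-fold lower number from compound 1 to compound 3 (0.40 log units; beyond the scatter) is modest, but it is the first change in this small series that goes beyond the scatter, and it comes from trifluoromethyl meta to a large group. Set against no change at the digits printed from compound 1 to compound 2 (within the scatter) with the same group on another carbon of that ring, it shows that swapping hydrogen for trifluoromethyl does not give one fixed result on this ring: among these compounds, the outcome depends on which carbon carries the group. Nothing measured here explains why this carbon differs from the other.

The compounds shown leave open whether a smaller group on this same carbon, such as a chlorine atom or a methoxy group, would also lower the number. They also leave open whether a nitrile there would do the same.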